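Decyl Chain in Place of a Dichlorophenylpropyl Arm

The source may hold more compounds than are shown below. What is called first, only, known or untested is meant among the compounds shown, and "the series" means these compounds.

Of the compounds shown here, two have so far been tested in a functional assay on cells (T-cell line, Homo sapiens) for inhibition; a higher number here means a weaker inhibitor, a lower number a stronger inhibitor. Compound 1, `COc1ccc(CCCN2CCC(COCc3ccc(Cl)cc3)CC2)cc1`, gives 500 nM in this assay. Compound 2, `Clc1ccc(CCCN2CCC(COC(c3ccccc3)c3ccccc3)CC2)cc1Cl`, gives 2200 nM in this assay, the higher of the two numbers; the gap to compound 1 lies beyond the scatter of repeated measurements. The two differ in several places at once, so no single step can be read between them.

Compound 3, `CCCCCCCCCCN1CCC(COC(c2ccccc2)c2ccccc2)CC1`, is the next compound to be measured in this assay. It differs from compound 2 by heptyl in place of 3,4-dichlorophenyl on a saturated chain carbon, three bonds along the chain from an amine nitrogen in a ring. Going by the values given here, nothing among the measured compounds shows what such a change does in this assay, so no direction can be drawn from them. Compound 3 is therefore expected to lie close to compound 2, with an expected step of a 1.1-fold higher number from compound 2 to compound 3 (0.06 log units; within the scatter) that need not exceed the scatter. The estimate for compound 3 is 2500 nM, with a range from 700 nM to 9000 nM.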

Compound 3, half-maximal inhibitory concentration: 2600 nM
The estimate for compound 3 lay 1.0-fold (0.02 log units) below the measured number, within the range that was stated.
By their numbers in this assay, from the lowest: compound 1; then compounds 2 and 3 (each within the scatter of the next).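

In this assay, the step is a 1.2-fold higher number from compound 2 to compound 3 (0.07 log units; within the scatter), so at this saturated chain carbon, three bonds along the chain from an amine nitrogen in a ring, heptyl stands in for 3,4-dichlorophenyl without moving the number beyond the scatter. With the rest of compound 2 kept, the aromatic ring and its two chlorines are therefore not required to retain this level of inhibition, and an open carbon chain serves equally well here. No independent measurement is available to explain why the two groups read alike.

Still open, from the compounds shown here alone, is how an unsubstituted phenyl, a shorter chain such as propyl, or a heptyl chain ending in an amine or a carboxylic acid would read at this position. Compound 1 differs from compound 3 in several places, so whether heptyl would be tolerated equally well on the core of compound 1 cannot be read.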